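Three level compounds and an untested 4-chlorophenyl analogue

The compounds below may be only part of what the source reports. "The series", "measured", "known", "first", "only" and "open" are said of these compounds alone.

In a functional assay on MV4-11 cells (Homo sapiens) for antiproliferative activity, read by luminescence and CellTiter-Glo, with a stated time of 72 h (on this read-out lower numbers stand for stronger inhibition and higher numbers for weaker inhibition), three compounds built on one shared core give closely similar results. Compound 1 `COc1cc(Nc2nn(C3CCCCO3)c3cc(-c4c(C)noc4C)ccc23)ccc1F` gives 9300 nM, compound 2 `Cc1noc(C)c1-c1ccc2c(Nc3ccc(F)cc3)nn(C3CCCCO3)c2c1` gives 9900 nM, and compound 3 `COc1cc(F)ccc1Nc1nn(C2CCCCO2)c2cc(-c3c(C)noc3C)ccc12` gives 8500 nM. Compound 3 therefore stands level with the other two, since its gaps to both lie within the scatter.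

Compound 4 `Cc1noc(C)c1-c1ccc2c(Nc3ccc(Cl)cc3)nn(C3CCCCO3)c2c1` differs from compound 3 in one place 4-chlorophenyl in place of 4-fluoro-2-methoxyphenyl on a nitrogen on an aromatic ring. The measured steps speak only to the methoxy part of this change. Placing methoxy on an aromatic carbon in place of hydrogen gave a 1.2-fold lower number from compound 2 to compound 3 (0.07 log units; within the scatter). Shifting the methoxy group, from 4-fluoro-3-methoxyphenyl to 4-fluoro-2-methoxyphenyl, gave a 1.1-fold lower number from compound 1 to compound 3 (0.04 log units; within the scatter). Replacing methoxy with hydrogen gave a 1.1-fold higher number from compound 1 to compound 2 (0.03 log units; within the scatter). All three are small and within the scatter. Among the compounds with values here, no measured step shows what chlorine in place of fluorine does, so the range must stay wide. No shift beyond the scatter is expected, in either direction, and the expected step is a 1.1-fold higher number from compound 3 to compound 4 (0.02 log units; within the scatter). For compound 4 the estimated value is 9000 nM, with an expected range of 4500 nM to 18000 nM.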

Compound 4, half-maximal inhibitory concentration: 7400 nM
For compound 4 the middle estimate is 1.2-fold (0.09 log units) above the measured one; the range from low to high includes it.
By their numbers in this assay, from the lowest: compounds 4, 3, 1 and 2 (each within the scatter of the next).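

In this assay, within the data shown here, the change from (4-fluoro-2-methoxyphenyl)amino to (4-chlorophenyl)amino gives a 1.1-fold lower number from compound 3 to compound 4 (0.06 log units; within the scatter), while chloro in place of fluoro, an exchange that no earlier pair covered, gives a 1.3-fold lower number from compound 2 to compound 4 (0.13 log units; within the scatter), and the change from 4-fluoro-3-methoxyphenyl to 4-chlorophenyl gives a 1.3-fold lower number from compound 1 to compound 4 (0.10 log units; within the scatter). The halogen on this phenyl ring can therefore now be added to the methoxy group as a feature whose change leaves the number level, so that all four compounds sit within the scatter of one another, even though the group on this nitrogen has now been varied in both its halogen and its methoxy group. Nothing available says why these changes leave the number level.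

From the compounds shown here alone, what stays open is whether any group on this nitrogen can move the number beyond the scatter, since all four compounds carry a halogen-bearing phenyl there. A phenyl ring carrying a carboxylic acid or an amine, bromo or trifluoromethyl in place of chloro, or a longer alkyl chain in place of the ring would each test this further.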